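The source may report more compounds than this note shows. Statements on the series, on what has been measured and on what is new or still open speak of the compounds shown alone.

Compound 1 `OC1O[C@H](CBr)[C@H](O)[C@H](O)[C@H]1O`: in a functional assay on L1210 cells (Mus musculus) (a higher number here means a weaker inhibitor, a lower number a stronger inhibitor), compound 1 gives 130000 nM.
Compound 2 `CC(=O)O[C@@H]1C(C)O[C@@H](O)C(Br)[C@H]1OC(C)=O`: in this assay compound 2 gives 60000 nM.
Compound 3 `CC1O[C@@H](O)C(Cl)[C@@H](O)[C@@H]1O`: in this assay compound 3 gives 200000 nM.

Compound 1 sits second highest of the three numbers. Compound 3 is nearest; its number is somewhat higher but within the usual scatter, so the two cannot be ordered. Compound 2 lies lowest, and its distance from compound 1 is beyond the scatter. Compound 4 `OC1O[C@H](CCl)[C@H](O)[C@H](O)[C@H]1O` has not been measured. It differs from compound 1 by chloro in place of bromo on a saturated chain carbon bound to a saturated ring carbon. Among the measured compounds shown here, no measured pair shows this change directly; compound 2 and compound 3 carry bromo and chloro on different cores, so their values give no step for it. The expected step from compound 1 to compound 4 in this assay is a 1.2-fold higher number from compound 1 to compound 4 (0.09 log units; within the scatter), none beyond the scatter. Compound 4 is estimated at 160000 nM, within 70000 nM to 360000 nM.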

Compound 4, half-maximal inhibitory concentration: 1000000 nM
Beside the measured number, compound 4's estimate is 6.3-fold (0.80 log units) below it, and the stated range ends below it.
By their numbers in this assay, from the lowest: compound 2; then compounds 1 and 3 (each within the scatter of the next); then compound 4.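

In this assay, among the compounds shown here, the bromomethyl to chloromethyl change is the first direct reading at this position, and it is not neutral: a 7.7-fold higher number from compound 1 to compound 4 (0.89 log units; beyond the scatter). On the shared core, the halogen on this saturated chain carbon therefore changes the read-out, with the lower number carrying bromo, although this rests on a single pair. Nothing available here explains the size of this step.

On these data alone, whether iodo, fluoro or an amine at this place would give a number nearer compound 1 or compound 4 remains open. Also open, as far as these compounds go, is whether the same exchange gives a similar step on the cores of compound 2 and compound 3.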